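This account rests on a few compounds, and the source may have more. Where it says the series, first, only, none or still open, it means among the compounds named here.

Measured compounds:
- compound 1, `Cn1c(CC(C)(C)C)nc2ccc(-n3ccc(OCc4ccc(F)cc4)cc3=O)cc21`: > 1000 nM
- compound 2, `Cn1c(C2CC2)nc2ccc(-n3ccc(OCc4cccc(Cl)c4)cc3=O)cc21`: 72 nM
- compound 3, `Cn1c(C2CC2)nc2ccc(-n3ccc(OCc4ccccc4Cl)cc3=O)cc21`: 140 nM

All three were tested in an assay on CHO cells for displacement of a labelled ligand from melanin-concentrating hormone receptor 1 (Rattus norvegicus), read by scintillation counting, with a stated time of 1 h; on this read-out lower numbers stand for stronger inhibition and higher numbers for weaker inhibition. The value of compound 1 is a limit of the assay, not a number, as described in the limit of > 1000 nM in this assay, at which 1 of the 3 values shown sits. Among the two numbers, compound 3 gives the higher one, yet the step of a 1.9-fold higher number from compound 2 to compound 3 (0.29 log units; within the scatter) is within the scatter, so compound 2 and compound 3 cannot be told apart on this read-out.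

Compound 4, `Cn1c(C2CC2)nc2ccc(-n3ccc(OCc4csc(Cl)c4)cc3=O)cc21`, has not yet been measured. It differs from compound 3 in one place: 5-chlorothiophen-3-yl in place of 2-chlorophenyl on a saturated chain carbon bound to an oxygen on an aromatic ring. Going by the values given here, the only measured step that touches this part of the molecule is a 1.9-fold higher number from compound 2 to compound 3 (0.29 log units; within the scatter), which moved a chlorine on the same phenyl ring and stayed within the scatter. Among the compounds with values here, no measured pair shows what swapping the phenyl ring for a thiophene ring does in this assay, so the expectation rests on the small size of the one known step in this region.

The step from compound 3 to compound 4 is therefore expected to be a 1.1-fold higher number from compound 3 to compound 4 (0.03 log units; within the scatter), with no clear direction. Compound 4 is estimated to give 150 nM in this assay, likely between 50 nM and 500 nM.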

Compound 4, half-maximal inhibitory concentration: 9.3 nM
Beside the measured number, compound 4's estimate is 16-fold (1.21 log units) above it, outside the stated range (below it).
By their numbers in this assay, from the lowest: compound 4; then compounds 2 and 3 (each within the scatter of the next). At a limit, above all of these: compound 1.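

In this assay, going by these compounds alone, the one earlier step at this position, a chlorine moved around the phenyl ring, stayed within the scatter, so the group on the saturated chain carbon bound to an oxygen on an aromatic ring looked insensitive to small edits. Replacing the whole ring tells a different story: 5-chlorothiophen-3-yl in place of 2-chlorophenyl gives a 15-fold lower number from compound 3 to compound 4 (1.18 log units; beyond the scatter) and is beyond the scatter, which makes this position far more responsive than the chlorine move suggested. The same group in place of 3-chlorophenyl gives a 7.7-fold lower number from compound 2 to compound 4 (0.89 log units; beyond the scatter) and also lies beyond the scatter, so the gain appears against both chlorinated phenyl compounds and does not depend on which of the two is the starting point.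

Still open, going by these compounds, is whether the chlorine on the thiophene ring contributes at all, and whether an unsubstituted thiophen-3-yl, a furan ring or a pyridine ring at the same place would keep the number this low. Nothing measured here explains why this ring swap lowers the number so sharply.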